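The source may report more compounds than this note shows. Statements on the series, on what has been measured and on what is new or still open speak of the compounds shown alone.

Measured compounds in an assay on HEK293 cells for positive allosteric modulation of metabotropic glutamate receptor 2 (Rattus norvegicus), read by thallium flux; a higher number here means a larger maximal response, a lower number a smaller maximal response:
compound 1 `O=C1c2ccc(OCc3cccc(-c4ccc(Cl)cc4F)c3)cc2CN1C1CCCC1`: "not determined" (no result reported)
compound 2 `Cn1sc2cc(OCc3cccc(-c4ccc(Cl)c(C(=O)O)c4)c3)ccc2c1=O`: 74.7%
compound 3 `O=C(O)c1cc(-c2cccc(COc3ccc4c(=O)n(C5CCC5)sc4c3)c2)ccc1Cl`: 83%

Compound 1 therefore stands nowhere on the numbers: it has no single value in this assay. Compound 4 `O=C(O)c1ccc(Cl)c(-c2cccc(COc3ccc4c(c3)CN(C3CCCC3)C4=O)c2)c1` differs from compound 1 by 5-carboxy-2-chlorophenyl in place of 4-chloro-2-fluorophenyl on an aromatic carbon. Among the measured compounds shown here, no measured step covers this change on the core of compound 1. For the measured compounds named here, the one step recorded, a number 8.3 percentage points higher from compound 2 to compound 3 (within the scatter), concerns the group on the aromatic nitrogen of a different core and bears on the present step only as a guide to the general level: with the 5-carboxy-2-chlorophenyl group in place, compound 2 gives 74.7% and compound 3 gives 83% in this assay. Carrying that level across, compound 4 is expected to reach about 80% in this assay, estimated between 60% and 100%.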

Compound 4, largest response reached (reported as percent of maximum), in percent of the reference or control that the assay uses: 93.9%
Compound 4: middle estimate off by 13.9 percentage points, on the low side, and the stated range covers the measured number.
By their numbers in this assay, from the lowest: compounds 2 and 3 (each within the scatter of the next); then compound 4.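

Among the compounds shown here, compound 1 has no number in this assay, so no step to compound 4 can be read. On these data alone, the effect of swapping 4-chloro-2-fluorophenyl for 5-carboxy-2-chlorophenyl on this core stays open. No evidence at hand bears on this result.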